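Exchanging the Group on the Amide Nitrogen: Compound 4

A few compounds are considered here, and "the series" means these few. Any claim that something is new, unique, unknown or untested is made for them only; others in the source may bear on it.

Of the compounds shown here, three have been tested in a functional assay on MCF7 cells (Homo sapiens) for inhibition; a lower number here means a stronger inhibitor of growth, a higher number a weaker inhibitor of growth. Compound 1 `O=C(COc1ccc(/C=C2\SC(=O)NC2=O)cc1)Nc1ccc([N+](=O)[O-])cc1` gives 72500 nM. Compound 2 `O=C(COc1ccc(/C=C2\SC(=O)NC2=O)cc1)Nc1ccc(F)cc1` gives 54600 nM, and compound 3 `Cc1ccc(NC(=O)COc2ccc(/C=C3\SC(=O)NC3=O)cc2)cc1Cl` gives 61800 nM. Compound 1 therefore stands nowhere apart from its two partners. The steps of a 1.3-fold lower number from compound 1 to compound 2 (0.12 log units; within the scatter) and a 1.2-fold lower number from compound 1 to compound 3 (0.07 log units; within the scatter) both fall within the scatter, as does a 1.1-fold higher number from compound 2 to compound 3 (0.05 log units; within the scatter), so all three numbers describe the same weak inhibition of growth.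

Compound 4 `O=C(COc1ccc(/C=C2\SC(=O)NC2=O)cc1)Nc1c(Cl)cccc1Cl` differs from compound 1 in one place: 2,6-dichlorophenyl in place of 4-nitrophenyl on an amide-type nitrogen. The measured steps that bear on this are the two earlier exchanges of the group on that same amide-type nitrogen, a 1.3-fold lower number from compound 1 to compound 2 (0.12 log units; within the scatter) and a 1.2-fold lower number from compound 1 to compound 3 (0.07 log units; within the scatter), each of which left the number within the scatter even though the entering groups carried quite different substituents. Nothing measured suggests that a third such exchange should behave differently, so no step beyond the scatter is expected in this assay in either direction. Compound 4 is therefore expected to give about 60000 nM, with a plausible range from 25000 nM to 150000 nM. This estimate amounts to a step of a 1.2-fold lower number from compound 1 to compound 4 (0.08 log units; within the scatter) that stays inside the scatter.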

Compound 4, concentration for 50% growth inhibition: 61700 nM
Beside the measured number, compound 4's estimate is 1.0-fold (0.01 log units) below it; the range from low to high includes it.
By their numbers in this assay, from the lowest: compounds 2, 4, 3 and 1 (each within the scatter of the next).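

In this assay, the exchange of 4-nitrophenyl for 2,6-dichlorophenyl on the amide-type nitrogen gives a 1.2-fold lower number from compound 1 to compound 4 (0.07 log units; within the scatter), even though the entering group has chlorine atoms and no hydrogen-bond acceptors, while the leaving group has a nitrogen, oxygen atoms and hydrogen-bond acceptors. Compound 4 also shows no separation from the two other partners, with a 1.0-fold lower number from compound 3 to compound 4 (0.00 log units; within the scatter) and a 1.1-fold higher number from compound 2 to compound 4 (0.05 log units; within the scatter). The earlier compounds shown here covered 4-nitrophenyl, 4-fluorophenyl and 3-chloro-4-methylphenyl, and adding the 2,6-dichlorophenyl group widens the set of substituted phenyl groups on this nitrogen without producing a step beyond the scatter, so none of the four compounds stands apart from the others.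

The data shown offer no explanation for this flat result. Going by these compounds, it remains open whether a group of another kind on this nitrogen, such as a cyclohexyl ring, a longer alkyl chain, or a phenyl ring carrying an amine or a carboxylic acid, would give a number beyond the scatter of these four, and whether a change in the shared core would do so.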